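A few compounds are considered here, and "the series" means these few. Any claim that something is new, unique, unknown or untested is made for them only; others in the source may bear on it.

Measured so far in a functional assay on OVCAR-3 cells (Homo sapiens) for inhibition, read by MTT assay, with a stated time of 24 h; on this read-out higher numbers stand for weaker inhibition and lower numbers for stronger inhibition (compound, value):
Compound 1 `CC1(C)[C@H]2CC[C@]1(C)N(Cc1cn(-c3ccc(O)cc3)nn1)C(=O)C2` (410 nM)
Compound 2 `CC1(C)[C@H]2CC[C@]1(C)N(Cc1cn(-c3ccccc3)nn1)C(=O)C2` (50 nM)

Of these two, compound 2 holds the lower number and so the stronger inhibition in this assay. Compound 3 `Cc1ccccc1-n1cc(CN2C(=O)C[C@@H]3CC[C@@]2(C)C3(C)C)nn1` differs from compound 2 by methyl in place of hydrogen on an aromatic carbon, which turns phenyl to 2-methylphenyl. Among the compounds with values here, only one measured step bears on this: an 8.2-fold lower number from compound 1 to compound 2 (0.91 log units; beyond the scatter), hydrogen in place of hydroxy on an aromatic carbon. It involves a different group, so it offers only a loose guide, and no methyl has been measured here. Compound 1 does suggest that a group added to that ring need not be neutral, so a small rise is expected rather than a large one. The expected change is a 1.6-fold higher number from compound 2 to compound 3 (0.20 log units; within the scatter) in this assay, toward weaker inhibition. For compound 3 the estimate is 80 nM with an expected range of 25 nM to 250 nM in this assay.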

Compound 3, half-maximal inhibitory concentration: 150 nM
For compound 3 the middle estimate is 1.9-fold (0.27 log units) below the measured one; measured number inside the range.
By their numbers in this assay, from the lowest: compound 2; then compound 3; then compound 1.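

In this assay the step of a 3.0-fold higher number from compound 2 to compound 3 (0.48 log units; beyond the scatter) shows that even a single methyl on this ring, ortho to a large group, moves the number beyond the scatter toward weaker inhibition, so the plain phenyl of compound 2 remains the best of the three. The loss is smaller than with the hydroxy group, as the step of a 2.7-fold lower number from compound 1 to compound 3 (0.44 log units; beyond the scatter) shows, although that comparison changes both the group and its place on the ring. Nothing measured on these compounds explains the effect of the methyl.

The compounds shown leave open whether the loss follows from the methyl itself or from its place on the ring, since 3-methylphenyl and 4-methylphenyl do not appear among them. They also leave open whether a fluorine, a methoxy group or an amine on this ring would match compound 2.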